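A few compounds are considered here, and "the series" means these few. Any claim that something is new, unique, unknown or untested is made for them only; others in the source may bear on it.

Of the compounds shown here, three that share one core have been tested so far in a functional assay on HT-29 cells (Homo sapiens) for antiproliferative activity, read by MTT assay, with a stated time of 24 h; on this read-out lower numbers stand for stronger inhibition and higher numbers for weaker inhibition. Among the measured compounds shown here, compound 2 `COc1ccc(C(=O)/C=C/c2ccc(N(C)C)cc2)c2c1C=CC(C)(C)O2` gives 1870 nM, the only true number available. Compound 1 `COc1ccc(C(=O)/C=C/c2cc(OC)c(OC)c(OC)c2)c2c1C=CC(C)(C)O2` gives > 10000 nM, which is a limit of the assay and not a number. Compound 3 `COc1ccc(C(=O)/C=C/c2ccc(N(c3ccccc3)c3ccccc3)cc2)c2c1C=CC(C)(C)O2` gives > 10000 nM, which is also a limit. Compound 2 therefore has no measured neighbour to be compared with directly.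

The next compound is compound 4 `COc1ccc(C(=O)/C=C/c2ccccc2)c2c1C=CC(C)(C)O2`, which differs from compound 2 in one place: hydrogen in place of dimethylamino on an aromatic carbon. Hydrogen takes the place of dimethylamino on an aromatic carbon, para to a large group. For the measured compounds named here, no measured pair shows what this change does, so any expectation is loose. Weaker inhibition is expected in this assay, with a rise in the number beyond the usual scatter, as compound 2 at 1870 nM is the only one of the three to give a number. The expected step is a 3.2-fold higher number from compound 2 to compound 4 (0.51 log units; beyond the scatter). For compound 4 the estimated value is 6000 nM, with an expected range of 1800 nM to 20000 nM.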

Compound 4, half-maximal inhibitory concentration: > 10000 nM
Compound 4 ended at the assay's limit (the forecaster's own chance of this, stated with the estimate: 45%); middle value at least 1.6-fold (0.22 log units) away from the limit.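

Among the compounds shown here, this gives the first measured pair at this position. On the aromatic ring, in this assay, hydrogen in place of dimethylamino produces an at least 5.3-fold higher number from compound 2 to compound 4 (0.72 log units; beyond the scatter), so the plain phenyl does not keep the activity seen with 4-(dimethylamino)phenyl. The value of compound 4 is a limit of the assay and not a number, so the step shows only the smallest possible loss, and its true size remains unknown: the limit of > 10000 nM in this assay, at which 3 of the 4 values shown sit.

The compounds shown leave open whether the dimethylamino group itself is needed or whether another amine on the same aromatic carbon, such as a plain amino group or a morpholine, would also give a measurable value. They also leave open whether any replacement could give stronger inhibition than compound 2.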